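Replacing an imidazole amide with a methoxyphenyl amide

The source may report more compounds than this note shows. Statements on the series, on what has been measured and on what is new or still open speak of the compounds shown alone.

Compound 1, `COc1ccc(-c2cnc(NC(=O)c3cnc[nH]3)n2C)cc1`: > 100000 nM
Compound 2, `Cc1cccc(-c2cnc(NC(=O)c3ccc(F)cc3)n2C)c1`: > 100000 nM
Compound 3, `Cn1c(-c2ccccc2)cnc1NC(=O)c1ccccc1Cl`: > 50000 nM

Of the compounds shown here, three built on a shared core have been tested in a toxicity assay on THP-1 cells (Homo sapiens) for inhibition; on this read-out higher numbers stand for lower toxicity in this test and lower numbers for higher toxicity in this test. For compound 1 the reading of > 100000 nM is a limit of the assay, not a measured number. For compound 2 the reading of > 100000 nM is likewise a limit. For compound 3 the reading of > 50000 nM is a limit as well. Compound 1 thus stands at the limit of > 100000 nM in this assay, at which 2 of the 3 values shown sit, shared with compound 2, while compound 3 sits at the limit of > 50000 nM in this assay, at which 1 of the 3 values shown sits. None of the three shows toxicity that could be quantified within the tested range in this assay.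

Compound 4, `COc1ccc(-c2cnc(NC(=O)c3cccc(OC)c3)n2C)cc1`, has not yet been tested. It differs from compound 1 in a single place: 3-methoxyphenyl in place of 1H-imidazol-5-yl on a carbonyl carbon. Compounds 2 and 3 already carry a six-membered carbon-only ring on the carbonyl carbon, and both stand at a limit. No measured step exists between any pair of these compounds, so the expected step of a number no higher from compound 1 to compound 4 (the limit leaves the size open) in this assay is none beyond the scatter. Compound 4 is therefore estimated at 100000 nM, with a range from 40000 nM to 300000 nM, and most likely it will again be reported only as a limit.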

Compound 4, half-maximal cytotoxic concentration: > 100000 nM
Compound 4 was reported as a limit; the forecaster's own chance of this, stated with the estimate: 80%; the middle value sits exactly at the limit.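

Compound 1 and compound 4 are both reported only as limits, so no step between them can be read: the limit of > 100000 nM in this assay, at which 3 of the 4 values shown sit.

As far as these compounds go, what stays open is the true half-maximal cytotoxic concentration of each of the four compounds, and whether 3-methoxyphenyl in place of 1H-imidazol-5-yl on the carbonyl carbon changes it at all.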